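Adding a Methoxy Group: What to Expect for Cytotoxicity

The source may hold more compounds than are shown below. What is called first, only, known or untested is meant among the compounds shown, and "the series" means these compounds.

Compound 1, `COc1cc2c(c(OC)c1O)C(=O)[C@H](O)[C@@H](c1ccc(O)cc1)O2`: -3.8%
Compound 2, `COc1ccc([C@@H]2Oc3cc(OC)c(O)c(OC)c3C(=O)[C@@H]2O)cc1OC`: 2.9%
Compound 3, `COc1ccc([C@@H]2Oc3cc(OC)c(OC)c(OC)c3C(=O)[C@@H]2O)cc1`: 0.6%

In a functional assay on PC-12 cells (Rattus norvegicus) for cytotoxicity, read by MTT assay, with stated times of 2 h and 4 h, tested at 8 ug/mL (on this read-out lower numbers stand for a weaker effect and higher numbers for a stronger effect at the one concentration tested), the three measured compounds give numbers that all lie within the usual scatter of one another, so none of them can be called more or less active than the others. Compound 3 holds the second highest of the three numbers; its nearest neighbour is compound 2, and the compound furthest from it is compound 1, yet both gaps fall within the scatter.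

Compound 4, `COc1ccc([C@@H]2Oc3cc(OC)c(OC)c(OC)c3C(=O)[C@@H]2O)cc1OC`, differs from compound 3 in a single place: methoxy in place of hydrogen on an aromatic carbon. Within the data shown here, no step between measured compounds shows what such a change does here. The measured numbers all cluster close to zero, and the step of a number 0.4 percentage points higher from compound 3 to compound 4 (within the scatter) is expected to be none beyond the scatter. Compound 4 is therefore estimated to give 1%, with a likely range from -8% to 10%.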

Compound 4, a percentage reported as activity, at one concentration (the size of the read-out at that concentration, not a potency): -2.5%
Compound 4: the middle estimate sits 3.5 percentage points above what was measured, within the range that was stated.
By their numbers in this assay, from the lowest: compounds 1, 4, 3 and 2 (each within the scatter of the next).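

Among these compounds, the first direct reading of methoxy in place of hydrogen on an aromatic carbon, ortho to a methoxy group and meta to a large group, is a number 3.1 percentage points lower from compound 3 to compound 4 (within the scatter) in this assay. The second reading, methyl in place of hydrogen on an oxygen on an aromatic ring, is a number 5.4 percentage points lower from compound 2 to compound 4 (within the scatter). Neither single change separates the two compounds it links at the one concentration tested, and no other measurement here offers an explanation for these two steps.

As far as these compounds go, whether this aromatic carbon would respond to a different group, such as an amine, a carboxylic acid or a longer chain, stays open, with only hydrogen and methoxy compared there. From the compounds shown here alone, whether the two changes would separate these compounds at any other concentration also stays open.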